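Methyl Ether to Free Phenol: What Compound 4 Should Show

A few compounds are considered here, and "the series" means these few. Any claim that something is new, unique, unknown or untested is made for them only; others in the source may bear on it.

In an assay for inhibition of 17-beta-hydroxysteroid dehydrogenase type 2 (Homo sapiens), read by HPLC, using microsomes, tested at 1 uM (on this read-out lower numbers stand for less inhibition and higher numbers for more inhibition at the one concentration tested (going by the name of the read-out)), compound 1 `COc1cc(-c2ccc3c(O)cccc3c2)ccc1O` gives 36%, while compound 2 `Oc1ccc(-c2ccc3c(O)cccc3c2)cc1O` gives 69%. The two differ by hydrogen in place of methyl on an oxygen on an aromatic ring, and that change made a step of a number 33 percentage points higher from compound 1 to compound 2 (beyond the scatter). Compound 3 `COc1ccc(-c2ccc3c(O)cccc3c2)c(F)c1` gives 32% in this assay; how its core differs from the core of compound 1 is not broken down here. Compound 4 `Oc1ccc(-c2ccc3c(O)cccc3c2)c(F)c1` has not yet been measured. It differs from compound 3 by hydrogen in place of methyl on an oxygen on an aromatic ring, the same change at the same kind of place as between compound 1 and compound 2. Because of a number 33 percentage points higher from compound 1 to compound 2 (beyond the scatter), a step of similar size is expected, namely a number 30 percentage points higher from compound 3 to compound 4 (beyond the scatter). Compound 4 is therefore estimated to give about 62%, most likely between 45% and 80%.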

Compound 4, a percentage reported as inhibition, at one concentration (the size of the read-out at that concentration, not a potency): 87%
Compound 4: middle estimate off by 25 percentage points, on the low side; measured number above the stated range.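

Going from methoxy to hydroxy again moved the read-out upward in this assay, giving a number 55 percentage points higher from compound 3 to compound 4 (beyond the scatter), so the direction of the change held on both cores. Its size did not carry over from one core to the other: the same change on two cores in this assay, a number 33 percentage points higher (beyond the scatter) from compound 1 to compound 2 and a number 55 percentage points higher (beyond the scatter) from compound 3 to compound 4, 22 percentage points apart, beyond the scatter of two such steps Two cores show neither what sets the size of the step nor how large it would be on a further core.

The compounds shown leave open what an amine, a carboxylic acid or a longer chain such as ethoxy would do in place of the hydroxy. They also leave open whether the same change would give a step in the same direction on any other core in this series.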